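A few compounds are considered here, and "the series" means these few. Any claim that something is new, unique, unknown or untested is made for them only; others in the source may bear on it.

Compounds measured in this assay:
- compound 1 `CCN(Cc1ccccc1)Cc1ccccc1C(=O)N(CC)CC`: 8210 nM
- compound 2 `CCN(Cc1ccccc1)Cc1nc2ccccc2c(-c2ccccc2)c1C(=O)N(CC)CC`: 373 nM
- compound 3 `CCCNC(=O)c1c(CN(CC)Cc2ccccc2)nc2ccccc2c1-c1ccccc1`: 872 nM

In an assay on brain with Translocator protein (Rattus norvegicus) as the target (a higher number here means a weaker inhibitor, a lower number a stronger inhibitor), compound 1 stands highest of the three, with compound 3 well below it and compound 2 lower still, both gaps beyond the scatter. Compound 4 `CCN(Cc1ccccc1)Cc1ccccc1C(=O)N(C)c1ccccc1` differs from compound 1 in one place: methyl(phenyl)amino in place of diethylamino on a carbonyl carbon. Going by the values given here, the only measured step at the amide is a 2.3-fold higher number from compound 2 to compound 3 (0.37 log units; beyond the scatter), which concerns a different entering group on a different core, so it bears on the present change only loosely; it shows that altering the amide substituent moves the number by a modest amount. A modest step, in either direction, is therefore expected, a 1.4-fold lower number from compound 1 to compound 4 (0.14 log units; within the scatter). Compound 4 is expected to give 6000 nM, with a range from 2000 nM to 20000 nM.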

Compound 4, half-maximal inhibitory concentration: > 10000 nM
Compound 4: a limit, no number (the forecaster's own chance of this, stated with the estimate: 10%); middle value at least 1.6-fold (0.22 log units) away from the limit.
By their numbers in this assay, from the lowest: compound 2; then compound 3; then compound 1. At a limit, above all of these: compound 4.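

In this assay, compound 4 gives a limit and not a number: the limit of > 10000 nM in this assay, at which 1 of the 4 values shown sits.

The step, an at least 1.2-fold higher number from compound 1 to compound 4 (0.08 log units; that floor lies within the scatter), has a floor that the printed scatter covers, so a real rise is not established. It does show that methyl(phenyl)amino in place of diethylamino on a carbonyl carbon brings no lower number on this core.

On these data alone, how far compound 4 lies past its limit remains open, as does whether methyl(phenyl)amino would read the same way on the core of compound 2. Also open, as far as these compounds go, is how dimethylamino or piperidin-1-yl would read on that carbonyl carbon.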